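The compounds below may be only part of what the source reports. "The series", "measured", "known", "first", "only" and "open" are said of these compounds alone.

Measured so far in an assay on Sf9 cells for inhibition of protein deacetylase HDAC6 (Homo sapiens), read by fluorescence, with a stated time of 40 min, tested at 100 nM; on this read-out higher numbers stand for more inhibition at the one concentration tested (going by the name of the read-out) and lower numbers for less inhibition:
compound 1, `O=C(NO)c1ccc(NCc2nc(-c3cc4ccccc4s3)nn2-c2ccccc2)cc1`: 65.5%
compound 2, `CCc1ccc(-c2nc(CNc3ccc(C(=O)NO)cc3)n(-c3ccccc3)n2)cc1`: 54.6%
compound 3, `Cc1ccc(-c2nc(CNc3ccc(C(=O)NO)cc3)n(-c3ccccc3)n2)s1`: 79.7%

Compound 3 stands highest of the three numbers; its nearest neighbour is compound 1, and compound 2 lies furthest below it. The two steps that lead to compound 3 both point the same way: a number 14.2 percentage points higher from compound 1 to compound 3 (beyond the scatter) and a number 25.1 percentage points higher from compound 2 to compound 3 (beyond the scatter), each beyond the scatter.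

Compound 4, `O=C(NO)c1ccc(NCc2nc(-c3ccccc3Cl)nn2-c2ccccc2)cc1`, is not yet measured. It differs from compound 3 in one place: 2-chlorophenyl in place of 5-methylthiophen-2-yl on an aromatic carbon. The step that bears most directly on this change runs the other way: from compound 2 to compound 3 a six-membered carbon-only ring gave way to the five-membered ring bearing a sulfur, and this assay rose, a number 25.1 percentage points higher from compound 2 to compound 3 (beyond the scatter). The step of a number 14.2 percentage points higher from compound 1 to compound 3 (beyond the scatter) likewise shows the five-membered ring on compound 3 ahead of a larger sulfur-containing ring system. Compound 4 now undoes that, putting a six-membered carbon-only ring back in, though with a chlorine rather than an ethyl group. The expectation for compound 4 is therefore a fall from compound 3 of roughly the size seen before, a number 21.7 percentage points lower from compound 3 to compound 4 (beyond the scatter). Compound 4 is expected to give about 58% in this assay, within a range of 44% to 72%.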

Compound 4, a percentage reported as inhibition, at one concentration (the size of the read-out at that concentration, not a potency): 75%
Compound 4: the middle estimate sits 17 percentage points below what was measured, outside the stated range (above it).
By their numbers in this assay, from the lowest: compound 2; then compounds 1, 4 and 3 (each within the scatter of the next, the first and the last beyond it).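

In this assay a six-membered carbon-only ring at this position does not by itself bring the low number of compound 2: with 2-chlorophenyl in place of 5-methylthiophen-2-yl, the step is a number 4.7 percentage points lower from compound 3 to compound 4 (within the scatter), so the five-membered aromatic ring with its sulfur is not required to stay within the scatter of compound 3. The two phenyl-type groups are separated by what they carry and where they carry it, with 2-chlorophenyl replacing 4-ethylphenyl giving a number 20.4 percentage points higher from compound 2 to compound 4 (beyond the scatter); the earlier contrast between compound 2 and compound 3 therefore cannot be read as one of ring size or ring type alone. The bicyclic group of compound 1 is also not separated from 2-chlorophenyl, the step being a number 9.5 percentage points higher from compound 1 to compound 4 (within the scatter), even though compound 1 and compound 3 lie apart beyond the scatter.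

Nothing shown gives a cause for any of these steps. From the compounds shown here alone, it remains open whether the chlorine, its place on the ring or the ethyl group accounts for the gap, a question that a plain phenyl, a 4-chlorophenyl or a phenyl ring bearing an amine at this position would bear on.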